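Adding a methyl to the sulfonyl phenyl ring

The source may report more compounds than this note shows. Statements on the series, on what has been measured and on what is new or still open speak of the compounds shown alone.

Measured so far:
- compound 1, `COc1n[nH]c2ncc(C#Cc3c(F)ccc(NS(=O)(=O)c4ccccc4)c3F)cc12`: 19.2 nM
- compound 2, `COc1n[nH]c2ncc(C#Cc3c(F)ccc(NS(=O)(=O)c4ccc(Cl)cc4)c3F)cc12`: 16.8 nM

Of the compounds shown here, two have been tested in an assay on cells for inhibition of mitogen-activated protein kinase kinase kinase 20 (Homo sapiens), read by ADP-Glo, with a stated time of 30 min; a higher number here means a weaker inhibitor, a lower number a stronger inhibitor. Compound 1 carries a plain phenylsulfonyl group and gives 19.2 nM; compound 2 carries chloro in place of hydrogen on that ring and gives 16.8 nM. The change from a 1.1-fold lower number from compound 1 to compound 2 (0.06 log units; within the scatter); the two numbers are equal within the scatter, so compound 1 has the higher number of the two only on paper.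

Compound 3, `COc1n[nH]c2ncc(C#Cc3c(F)ccc(NS(=O)(=O)c4cccc(C)c4)c3F)cc12`, has not been measured. It differs from compound 1 in a single spot: methyl in place of hydrogen on an aromatic carbon. A one-carbon group enters the same phenylsulfonyl ring where chloro entered in compound 2, though at a different carbon. Among the measured compounds shown here, the only step that bears on it is the one from compound 1 to compound 2, which was within the scatter. A similarly small group on the same ring is therefore expected to leave the number roughly where compound 1 stands, and the estimated step from compound 1 to compound 3 is a 1.1-fold lower number from compound 1 to compound 3 (0.03 log units; within the scatter). Compound 3 is expected to give about 18 nM, with a range from 8 nM to 40 nM.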

Compound 3, half-maximal inhibitory concentration: 12.1 nM
For compound 3 the middle estimate is 1.5-fold (0.17 log units) above the measured one; low and high end bracket the measured number.
By their numbers in this assay, from the lowest: compounds 3, 2 and 1 (each within the scatter of the next).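

In this assay, methyl on the aromatic carbon meta to a large group gives a 1.6-fold lower number from compound 1 to compound 3 (0.20 log units; within the scatter), so this ring carbon accepts a small carbon group without a change that can be told from assay noise. Exchanging one substituted ring for the other, 3-methylphenyl in place of 4-chlorophenyl on the sulfonyl sulfur, gives a 1.4-fold lower number from compound 2 to compound 3 (0.14 log units; within the scatter), which means that three different versions of this ring now sit together within the scatter, and both the group and its carbon differ in this step, so their shares cannot be separated. No measurement here accounts for any of these numbers.

The compounds shown leave open whether methyl and chloro would read alike if both sat on one and the same ring carbon, a comparison that would separate the group from its place. They also leave open whether something quite different on this ring, such as an amine, a carboxylic acid or a longer chain like propyl, would move the number beyond the scatter, in either direction.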